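The source may report more compounds than this note shows. Statements on the series, on what has been measured and on what is new or still open speak of the compounds shown alone.

Measured in an ADME assay on microsomes from liver (Homo sapiens) for metabolic stability, using NADPH, with a stated time of 30 min, in the presence of a further agent that is not named here; a lower number here means that less of the compound is left, a higher number that more of the compound is left:
- compound 1 `O=S(=O)(c1ccc(Cl)cc1)N1Cc2c[nH]nc2CC1c1cccc(F)c1` gives 14%
- compound 2 `CC[C@H]1Cc2n[nH]cc2CN1S(=O)(=O)c1ccc(Cl)cc1` gives 18%

Both numbers are low. The gap between compound 1 and compound 2 lies within the usual scatter, so the two count as alike; compound 1 merely holds the smaller of the two values, and that carries no real order. Going by the values given here, no pair of measured compounds differing in one place is available, so the series offers no measured step to lean on.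

Compound 3 `O=S(=O)(c1ccc(Cl)cc1)N1Cc2c[nH]nc2CC1c1ccc(Cl)cc1` is the unmeasured member. It differs from compound 1 by 4-chlorophenyl in place of 3-fluorophenyl on a saturated ring carbon. Both measured compounds share the core and sit low in this assay, and an exchange of one phenyl group for another on the same saturated ring carbon is not expected to move the number beyond the scatter, in either direction. Compound 3 is therefore expected to give 13%, within 5% to 25%. The expected step is a number 1 percentage points lower from compound 1 to compound 3 (within the scatter), that is, none beyond the scatter.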

Compound 3, percent of the compound remaining: 12%
Estimate against measurement, compound 3: 1 percentage points above; measured number inside the range.
By their numbers in this assay, from the lowest: compounds 3, 1 and 2 (each within the scatter of the next).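

In this assay, going by these compounds alone, 4-chlorophenyl in place of 3-fluorophenyl on the saturated ring carbon next to the ring nitrogen gives a number 2 percentage points lower from compound 1 to compound 3 (within the scatter) and so provides the first measured step at this position. With the shared core held constant, this exchange of one substituted phenyl group for another leaves the two compounds alike, and both numbers stay low. Nothing measured here explains why the numbers stay low.

The compounds shown leave open whether a group other than a substituted phenyl on this ring carbon, such as an amine, a carboxylic acid or a longer chain, would move the number beyond the scatter. They also do not show whether a replacement of the 4-chlorophenyl on the sulfonyl group, for instance by a pyridine, would do so.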